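The source may report more compounds than this note shows. Statements on the series, on what has been measured and on what is new or still open speak of the compounds shown alone.

Compound 2 `COc1ccc(CN2CCN(CC(=O)Nc3ccc(-c4nc(-c5ccccc5)c(-c5ccccc5)n4C)cc3)CC2)cc1` carries a 4-methoxybenzyl group on an amine nitrogen in a ring. In a functional assay on MCF7 cells (Homo sapiens) for cytotoxicity, read by MTT assay, with a stated time of 24 h, tested at 6.4 ug/mL (a higher number here means a stronger effect of the compound at the concentration tested, a lower number a weaker effect), compound 2 gives 29%, the higher of the two measured numbers. Compound 1 `CN(C)/C=C/N1CCN(CC(=O)Nc2ccc(-c3nc(-c4ccccc4)c(-c4ccccc4)n3C)cc2)CC1` gives 11.1% in this assay, and the step of a number 17.9 percentage points higher from compound 1 to compound 2 (beyond the scatter) separates them. Compound 3 `Cn1c(-c2ccc(NC(=O)CN3CCN(Cc4ccc(Cl)cc4)CC3)cc2)nc(-c2ccccc2)c1-c1ccccc1` differs from compound 2 only by chloro in place of methoxy on an aromatic carbon. For the measured compounds named here, no measured step alters a substituent on that benzyl ring, so the one recorded step does not bear on this exchange. Compound 3 is expected to stay near that level, with an estimated step of a number 1 percentage points higher from compound 2 to compound 3 (within the scatter) and an estimated value of 30%, in a range from 12% to 50%.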

Compound 3, a percentage reported as activity, at one concentration (the size of the read-out at that concentration, not a potency): 33.4%
Compound 3: the middle estimate sits 3.4 percentage points below what was measured, and the stated range covers the measured number.
By their numbers in this assay, from the lowest: compound 1; then compounds 2 and 3 (each within the scatter of the next).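

In this assay, chloro in place of methoxy on the benzyl ring gives a number 4.4 percentage points higher from compound 2 to compound 3 (within the scatter), so this exchange does not separate the two compounds. The 4-chlorobenzyl group also stands clear of 2-(dimethylamino)ethenyl, with a number 22.3 percentage points higher from compound 1 to compound 3 (beyond the scatter), which means both benzyl compounds lie apart from compound 1. No measurement at hand offers a reason for either step. Still open, from the compounds shown here alone, is whether an amine or a carboxylic acid at this place on the ring would read differently, and whether a benzyl ring with only hydrogen there would hold the same level.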